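The source may hold more compounds than are shown below. What is called first, only, known or untested is meant among the compounds shown, and "the series" means these compounds.

Compound 3 `CCCCC#Cc1cn(C/C=C/CN2C(=O)c3ccccc3C2=O)c(=O)[nH]c1=O` gives 171000 nM in a functional assay on MOLT-4 cells (Homo sapiens) for antiproliferative activity, read by MTT assay, with a stated time of 3 days (a lower number here means a stronger inhibitor, a higher number a weaker inhibitor), the highest of the three numbers shown. Compound 2 `O=C1c2ccccc2C(=O)N1C/C=C\Cn1cc(C#Cc2ccc(Br)cc2)c(=O)[nH]c1=O` gives 89000 nM, and compound 1 `CCCCCCCCC#Cc1cn(C/C=C\CN2C(=O)c3ccccc3C2=O)c(=O)[nH]c1=O` gives 36000 nM. Compound 4 `CCCCCC#Cc1cn(C/C=C/CN2C(=O)c3ccccc3C2=O)c(=O)[nH]c1=O` differs from compound 3 by methyl in place of hydrogen on a saturated chain carbon, four bonds along the chain from a triple-bonded carbon. For the measured compounds named here, the only step measured in one place, a 2.5-fold higher number from compound 1 to compound 2 (0.39 log units; beyond the scatter), concerns a different position and does not touch this change directly. Compound 1, which carries an octyl group where compound 3 carries a shorter chain, shows a lower number than compound 3, but the two also differ elsewhere, so that comparison offers only a loose hint. The step of a 1.6-fold lower number from compound 3 to compound 4 (0.19 log units; within the scatter) is therefore expected to be small, leaning toward a lower number. Compound 4 is estimated at 110000 nM, within 40000 nM to 300000 nM.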

Compound 4, half-maximal inhibitory concentration: > 500000 nM
Compound 4 ended at the assay's limit; the forecaster's own chance of this, stated with the estimate: 10%; at least 4.5-fold (0.65 log units) between middle value and limit.
By their numbers in this assay, from the lowest: compound 1; then compounds 2 and 3 (each within the scatter of the next). At a limit, above all of these: compound 4.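

In this assay, for the compounds shown here, methyl in place of hydrogen at this saturated chain carbon gives an at least 2.9-fold higher number from compound 3 to compound 4 (0.46 log units; beyond the scatter), so even this small change at the chain's far end can raise the number beyond the scatter, which the earlier compounds could not show. Compound 4 stands at a limit of the assay, not at a number: the limit of > 500000 nM in this assay, at which 1 of the 4 values shown sits.

The compounds shown leave open how a shorter propyl chain, or an amine or a carboxylic acid at this chain carbon, would read. A single step also sets no trend with chain length.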